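Removing the propyl group from a thiophene-bearing amine

This account rests on a few compounds, and the source may have more. Where it says the series, first, only, none or still open, it means among the compounds named here.

Of the compounds shown here, three sharing one amine core have been tested in an ADME assay on MDCK cells (Canis lupus familiaris) for cytotoxicity, read by microscopy, with a stated time of 48 h; on this read-out higher numbers stand for lower toxicity in this test and lower numbers for higher toxicity in this test. Compound 1 `CSc1ccc(CN[C@@H]2C[C@H]3C[C@@H]([C@H]2C)C3(C)C)s1` gives 25000 nM. Compound 2 `CCCc1ccsc1CN[C@@H]1C[C@H]2C[C@@H]([C@H]1C)C2(C)C` gives 50000 nM. Compound 3 `C[C@H]1[C@H](NCc2ccc(Cl)s2)C[C@H]2C[C@@H]1C2(C)C` gives 25000 nM. The number for compound 2 differs from those of compound 1 and compound 3 only within the usual scatter, so on the numbers shown compound 2 cannot be set apart from the other two.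

Compound 4 `C[C@H]1[C@H](NCc2cccs2)C[C@H]2C[C@@H]1C2(C)C` has not yet been measured in this assay. It differs from compound 2 in one place: hydrogen in place of propyl on an aromatic carbon

Among the measured compounds shown here, only one measured step is available to judge this change. Going from compound 1 to compound 3, no change at the digits printed from compound 1 to compound 3 (within the scatter). That step swaps one small group on the ring for another, whereas the change to compound 4 removes a group entirely, so it is at best a loose guide. Still, it shows that altering the substituent on this ring left this assay unchanged, and nothing in the data points to a shift in either direction.

The step from compound 2 to compound 4 is therefore expected to be a 1.4-fold lower number from compound 2 to compound 4 (0.15 log units; within the scatter). For compound 4 the estimate in this assay is 35000 nM, with a range from 12500 nM to 100000 nM.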

Compound 4, minimum cytotoxic concentration: 25000 nM
Compound 4: the middle estimate sits 1.4-fold (0.15 log units) above what was measured; the measured number falls inside the stated range.
By their numbers in this assay, from the lowest: compounds 1, 3, 4 and 2 (each within the scatter of the next).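

With the propyl group gone from this ring carbon, two ring bonds from the ring sulfur, the reading in this assay still does not separate the two compounds, the step being a 2.0-fold lower number from compound 2 to compound 4 (0.30 log units; within the scatter). A thiophene ring bearing none of these groups also cannot be told apart from the rings carrying chloro or methylsulfanyl, with hydrogen in place of chloro giving no change at the digits printed from compound 3 to compound 4 (within the scatter) and hydrogen in place of methylsulfanyl giving no change at the digits printed from compound 1 to compound 4 (within the scatter). The earlier compounds shown here showed only one substituent exchanged for another, whereas these steps show that, among the four compounds, having no such group at all leaves the reading within the scatter of every substituted ring.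

Nothing measured here bears on why this test stays so flat across these compounds. On these data alone, it remains open whether an amine or a carboxylic acid on this ring carbon, or a chain longer than propyl, would carry the number beyond the scatter, and whether the same holds on a different core.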